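Chloro addition on the benzyl ring of compound 3

The source may report more compounds than this note shows. Statements on the series, on what has been measured and on what is new or still open speak of the compounds shown alone.

The shared core carries an ether-linked aryl or aroyl group. In a functional assay on HEK293 cells for agonist activity at G-protein coupled receptor 39 (Homo sapiens), read by scintillation proximity assay and inositol phosphate accumulation, with a stated time of 75 min, in the presence of a further agent that is not named here (on this read-out lower numbers stand for an effect already at smaller amounts and higher numbers for an effect only at larger amounts of compound), compound 1 `Cc1nn(-c2ncnc3nc[nH]c23)c2c1C(OCC(=O)c1ccc(F)cc1)CC(=O)N2` gives 3 nM, compound 2 `Cc1nn(-c2ncnc3nc[nH]c23)c2c1C(OCc1cc(F)cc3c1OCOC3)CC(=O)N2` gives 1.5 nM, and compound 3 `Cc1nn(-c2ncnc3nc[nH]c23)c2c1C(OCc1ccccc1Cl)CC(=O)N2` gives 2 nM. Compound 3 holds the second highest of these three numbers; the nearest is a 1.3-fold higher number from compound 2 to compound 3 (0.12 log units; within the scatter), the furthest a 1.5-fold lower number from compound 1 to compound 3 (0.18 log units; within the scatter), so all three values sit together.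

Compound 4 `Cc1nn(-c2ncnc3nc[nH]c23)c2c1C(OCc1ccc(Cl)cc1Cl)CC(=O)N2` differs from compound 3 by chloro in place of hydrogen on an aromatic carbon. No measured step adds a single substituent on the aromatic ring; the steps shown, a 2.0-fold lower number from compound 1 to compound 2 (0.30 log units; within the scatter), a 1.5-fold lower number from compound 1 to compound 3 (0.18 log units; within the scatter) and a 1.3-fold higher number from compound 2 to compound 3 (0.12 log units; within the scatter), each exchange the whole group on the ether oxygen, and none reaches beyond the scatter. They only indicate that this position tolerates varied groups without a shift in this assay. A move beyond the scatter is therefore not expected in either direction. The expected step reads no change at the digits printed from compound 3 to compound 4 (within the scatter). Compound 4 is estimated at 2 nM in this assay, in the range 0.7 nM to 6 nM.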

Compound 4, half-maximal effective concentration: 4 nM
Compound 4: middle estimate off by 2.0-fold (0.30 log units), on the low side; low and high end bracket the measured number.
By their numbers in this assay, from the lowest: compounds 2, 3, 1 and 4 (each within the scatter of the next, the first and the last beyond it).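

Chloro in place of hydrogen, para to a large group on the ring of compound 3, is the first single-substituent change in the series, and in this assay it stays within the scatter (a 2.0-fold higher number from compound 3 to compound 4 (0.30 log units; within the scatter)). Among the exchanges of the whole group on the ether oxygen, compound 4 gives the first modest step beyond the scatter (a 2.7-fold higher number from compound 2 to compound 4 (0.43 log units; beyond the scatter)), while its step from the aroyl compound stays within it (a 1.3-fold higher number from compound 1 to compound 4 (0.12 log units; within the scatter)), so the tolerance seen so far holds against compounds 1 and 3 but not against compound 2. No measurement offered here accounts for these steps.

Still open, going by these compounds, is whether an amine, a carboxylic acid or a methoxy group on this same ring carbon would stay within the scatter. Also open, on these data alone, is how a 4-chlorobenzyl group, without the second chloro, would compare with the 2,4-dichlorobenzyl group of compound 4.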